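This account rests on a few compounds, and the source may have more. Where it says the series, first, only, none or still open, it means among the compounds named here.

Among the compounds with values here, compound 2 `CCCNc1nc(NCc2ccc(C(=O)N3CCC(C(=O)NCc4ccc(F)cc4)CC3)cc2)c2cc(C)ccc2n1` carries the highest number of the two measured so far in a functional assay on HCT-116 cells (Homo sapiens) for inhibition, read by luminescence and resazurin assay, with a stated time of 3 days (on this read-out lower numbers stand for stronger inhibition and higher numbers for weaker inhibition), where compound 2 gives 4600 nM; compound 1 `CNc1nc(NCc2ccc(C(=O)NC3CCN(Cc4ccc(F)cc4)CC3)cc2)c2cc(C)ccc2n1` gives 1200 nM in this assay, a lower number beyond the scatter. Compound 3 `Cc1ccc2nc(N(C)C)nc(NCc3ccc(C(=O)N4CCC(C(=O)NCc5ccc(F)cc5)CC4)cc3)c2c1` differs from compound 2 by dimethylamino in place of propylamino on an aromatic carbon. Within the data shown here, no step between measured compounds covers this change, so its size cannot be read from the numbers; a shift in this assay of no more than the scatter, in either direction, is expected. Compound 3 is therefore estimated at 4000 nM, within 1500 nM to 12000 nM. This corresponds to an expected step of a 1.2-fold lower number from compound 2 to compound 3 (0.06 log units; within the scatter).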

Compound 3, half-maximal inhibitory concentration: 5600 nM
For compound 3 the middle estimate is 1.4-fold (0.15 log units) below the measured one; the range from low to high includes it.
By their numbers in this assay, from the lowest: compound 1; then compounds 2 and 3 (each within the scatter of the next).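

At the aromatic carbon between two ring nitrogen atoms, dimethylamino in place of propylamino gives a 1.2-fold higher number from compound 2 to compound 3 (0.09 log units; within the scatter) in this assay. Within the data shown here, this is the first single-place read at this position: the swap takes away the one hydrogen-bond donor of propylamino, and this assay does not separate the two groups. Nothing measured here offers a reason for this.

Open, as far as these compounds go, is whether a ring-bearing amine such as morpholine, or a longer chain such as hexylamino, would stay level with these two groups. Also open, from the compounds shown here alone, is whether the unsubstituted amino group would do the same.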